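Aryl sulfonate to benzylic sulfone at the phenyl ether terminus

The source may report more compounds than this note shows. Statements on the series, on what has been measured and on what is new or still open speak of the compounds shown alone.

Measured compounds:
compound 1 `C[C@@H]1CN(c2nnc(C(F)(F)F)o2)CCN1c1ncc(OCc2ccc(OS(C)(=O)=O)cc2F)cn1` — in a functional assay on HEK293S cells for agonist activity at Glucose-dependent insulinotropic receptor (Homo sapiens), read by HTRF and cAMP accumulation, with a stated time of 45 min (a higher number here means that more compound is needed for the effect, a lower number that less compound is needed), compound 1 gives 4 nM
compound 2 `C[C@@H]1CN(C(=O)OC2(C(F)(F)F)COC2)CCN1c1ncc(OCc2ccc(OS(C)(=O)=O)cc2F)cn1` — in this assay compound 2 gives 4 nM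

Compound 2 stands level with compound 1 at the digits shown; the only measured step, no change at the digits printed from compound 1 to compound 2 (within the scatter), concerns the exchange on the amine nitrogen in the ring and lies within the scatter. Compound 3 `C[C@@H]1CN(C(=O)OC2(C(F)(F)F)COC2)CCN1c1ncc(OCc2ccc(CS(C)(=O)=O)cc2F)cn1` keeps the amine substituent of compound 2 and changes the other end: (methylsulfonyl)methyl in place of (methylsulfonyl)oxy on an aromatic carbon. For the measured compounds named here, no measured step touches this position, so nothing in hand tells how large a step to expect in this assay, nor its direction. Absent such a step, the working assumption is a change no larger than the scatter. For compound 3 the expected value in this assay is 6 nM, with a range from 2 nM to 20 nM, which is estimated to mean a step of a 1.5-fold higher number from compound 2 to compound 3 (0.18 log units; within the scatter) from compound 2.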

Compound 3, half-maximal effective concentration in the Glucose-dependent insulinotropic receptor assay: 20 nM
Compound 3: the middle estimate sits 3.3-fold (0.52 log units) below what was measured; the measured number falls inside the stated range.
By their numbers in the Glucose-dependent insulinotropic receptor assay, from the lowest: compounds 1 and 2 (each within the scatter of the next); then compound 3.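

For the compounds shown here, this position is not neutral, unlike the amine nitrogen, where the only earlier step was no change at the digits printed from compound 1 to compound 2 (within the scatter): in the Glucose-dependent insulinotropic receptor assay, (methylsulfonyl)methyl in place of (methylsulfonyl)oxy gives a 5.0-fold higher number from compound 2 to compound 3 (0.70 log units; beyond the scatter). The same exchange also changes the reading in a physicochemical assay for lipophilicity, in phosphate buffer, at pH 7.4 (a higher number here means a more lipophilic compound, a lower number a more polar compound), where compound 2 gives 3.7 and compound 3 gives 2.9: the measured distribution coefficient of compound 2, 3.7, and of compound 3, 2.9, a number 0.80 log units lower (beyond the scatter) Both steps therefore move together across this one matched pair, with compound 3 the more polar of the two and needing more compound for the effect.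

A single pair cannot show whether the two steps are linked, or whether the step in the Glucose-dependent insulinotropic receptor assay would be the same size with 5-(trifluoromethyl)-1,3,4-oxadiazol-2-yl on the amine nitrogen. Also open, as far as these compounds go, is how a sulfonamide, or a longer chain carrying the methylsulfonyl group, would behave on this aromatic carbon in both assays.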